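Trifluoromethoxy for trifluoromethyl on compound 2

The compounds below may be only part of what the source reports. "The series", "measured", "known", "first", "only" and "open" are said of these compounds alone.

Measured in a functional assay on LNCaP cells (Homo sapiens) for antiproliferative activity, read by propidium iodide staining, with a stated time of 96 h; on this read-out higher numbers stand for weaker inhibition and lower numbers for stronger inhibition:
- compound 1 `CC(O)(COc1cccc(S(F)(F)(F)(F)F)c1)C(=O)Nc1ccc(C#N)c(C(F)(F)F)c1` gives 9800 nM
- compound 2 `CC(O)(CS(=O)(=O)c1ccccc1C(F)(F)F)C(=O)Nc1cccc(S(F)(F)(F)(F)F)c1` gives 24900 nM

Of these two compounds, compound 2 has the higher number and so the weaker inhibition in this assay, and its gap to compound 1 lies beyond the scatter.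

Compound 3 `CC(O)(CS(=O)(=O)c1ccccc1OC(F)(F)F)C(=O)Nc1cccc(S(F)(F)(F)(F)F)c1` is not yet measured. It differs from compound 2 in one place: trifluoromethoxy in place of trifluoromethyl on an aromatic carbon. This is trifluoromethoxy in place of trifluoromethyl on an aromatic carbon, ortho to a large group.

For the measured compounds named here, no measured pair shows this change, so the data give no size or direction for it. In this assay, no change beyond the scatter is expected. The expected step is small: a 1.2-fold lower number from compound 2 to compound 3 (0.07 log units; within the scatter). The estimate for compound 3 is 21000 nM, with an expected range of 9000 nM to 48000 nM.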

Compound 3, half-maximal inhibitory concentration: 9000 nM
The estimate for compound 3 lay 2.3-fold (0.37 log units) above the measured number; the range from low to high includes it.
By their numbers in this assay, from the lowest: compounds 3 and 1 (each within the scatter of the next); then compound 2.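

In this assay, for the compounds shown here, trifluoromethoxy in place of trifluoromethyl on an aromatic carbon, ortho to a large group, gives a 2.8-fold lower number from compound 2 to compound 3 (0.44 log units; beyond the scatter); the earlier compounds gave no size or direction for this change, and this pair shows that the position responds to it. The reading rests on this one pair in the shared core, so no wider pattern follows from it. No measured property of either group is at hand to account for the step.

Still open, on these data alone, is whether methoxy, a chlorine atom or a carboxylic acid on the same aromatic carbon would move the number in the same direction. Also open, as far as these compounds go, is whether the same change gives a similar step when the amide nitrogen carries the nitrile-bearing aromatic ring of compound 1.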